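The source may report more compounds than this note shows. Statements on the series, on what has been measured and on what is new or still open speak of the compounds shown alone.

Measured compounds:
Compound 1 `CCCn1c(=O)[nH]c2nc(-c3ccc(S(=O)(=O)N4CCN(c5ccc(F)cc5)CC4)cc3)[nH]c2c1=O`: 38%
Compound 2 `CCCn1c(=O)[nH]c2nc(-c3ccc(S(=O)(=O)N4CCN(C)CC4)cc3)[nH]c2c1=O`: 7%
Compound 3 `CCCn1c(=O)[nH]c2nc(-c3ccc(S(=O)(=O)N4CCN(c5ccc(C)cc5)CC4)cc3)[nH]c2c1=O`: 25%

In an assay on CHO cells for displacement of a labelled ligand from adenosine receptor A3 (Homo sapiens), read by scintillation counting, with a stated time of 45 min, tested at 1 uM, in the presence of a further agent that is not named here (a lower number here means less inhibition, a higher number more inhibition at the concentration tested (going by the name of the read-out)), compound 1 stands highest of the three, with compound 3 nearest and compound 2 furthest. The step of a number 31 percentage points lower from compound 1 to compound 2 (beyond the scatter) shows that replacing the 4-fluorophenyl on the ring amine nitrogen with a methyl removes most of the inhibition, while a number 18 percentage points higher from compound 2 to compound 3 (beyond the scatter) shows that putting a 4-methylphenyl in the place of that methyl restores a good part of it. The smaller step of a number 13 percentage points lower from compound 1 to compound 3 (beyond the scatter) shows that exchanging fluoro for methyl on the aromatic carbon also lowers the number.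

Compound 4 `CCCn1c(=O)[nH]c2nc(-c3ccc(S(=O)(=O)N4CCN(Cc5ccc(Br)c(F)c5)CC4)cc3)[nH]c2c1=O` differs from compound 1 in one place: 4-bromo-3-fluorobenzyl in place of 4-fluorophenyl on an amine nitrogen in a ring. Among the compounds with values here, no measured pair covers a benzyl group on this nitrogen, so the two aryl-bearing steps are the closest guide. Both aryl-bearing compounds, compound 1 and compound 3, sit well above compound 2, and the incoming group again carries an aromatic ring with a halogen. The expectation is therefore a number in the same region as compound 1 or somewhat lower, giving an estimated step of a number 8 percentage points lower from compound 1 to compound 4 (within the scatter). Compound 4 is accordingly expected to give about 30% in this assay, within a range from 10% to 52%.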

Compound 4, a percentage reported as inhibition, at one concentration (the size of the read-out at that concentration, not a potency): 27%
Beside the measured number, compound 4's estimate is 3 percentage points above it; low and high end bracket the measured number.
By their numbers in this assay, from the lowest: compound 2; then compounds 3 and 4 (each within the scatter of the next); then compound 1.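

The 4-bromo-3-fluorobenzyl group shows that a directly attached aryl ring is not needed on this amine nitrogen in a ring to stay clear of the methyl compound in this assay, since the benzyl compound gives a number 20 percentage points higher from compound 2 to compound 4 (beyond the scatter) and so keeps a modest step over the methyl group. Measured against the 4-fluorophenyl group, the same change gives a number 11 percentage points lower from compound 1 to compound 4 (beyond the scatter) as a modest loss, although the entering group brings more heavy atoms and an added bromine, so a larger group here did not give a larger number. Against the 4-methylphenyl group there is a number 2 percentage points higher from compound 3 to compound 4 (within the scatter) and thus no difference that can be read, which means this benzyl group and that aryl group cannot be told apart here, and nothing measured offers a reason for any of these steps.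

The compounds shown leave open whether the benzyl link or the two halogens on its ring set the number, as an unsubstituted benzyl group would be needed to separate them. They also leave open how a nitrogen-containing ring such as pyridine, or a carboxylic acid, would read on this nitrogen.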